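This account rests on a few compounds, and the source may have more. Where it says the series, first, only, none or still open, it means among the compounds named here.

The measured compounds in a functional assay on the whole organism (Tail, strain ICR) with Mus musculus as the target, in the tail flick test, with a stated time of 60 min, at a dose of 25 umol/kg by the oral route; on this read-out lower numbers stand for a weaker effect and higher numbers for a stronger effect at the one dose given:
compound 1 `O=C(CN(c1nc(Cl)nc2[nH]cnc12)C1CC1)N[C@@H](CO)C(=O)OCc1ccccc1` gives 34.2%.
compound 2 `CC(C)[C@H](NC(=O)CN(c1nc(Cl)nc2[nH]cnc12)C1CC1)C(=O)OCc1ccccc1` gives 55.5%.
compound 3 `CC[C@H](C)[C@H](NC(=O)CN(c1nc(Cl)nc2[nH]cnc12)C1CC1)C(=O)OCc1ccccc1` gives 40.6%.

Compound 3 stands second highest of these three numbers. Its nearest neighbour is compound 1, with a number 6.4 percentage points higher from compound 1 to compound 3 (within the scatter), and its furthest is compound 2, with a number 14.9 percentage points lower from compound 2 to compound 3 (beyond the scatter).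

Compound 4 is `CC(C)C[C@H](NC(=O)CN(c1nc(Cl)nc2[nH]cnc12)C1CC1)C(=O)OCc1ccccc1` and has not yet been measured. It differs from compound 3 by isobutyl in place of sec-butyl on a saturated chain carbon bound to an amide-type nitrogen and a carbonyl carbon, so the same atoms of the side chain are kept and only joined differently.

For the measured compounds named here, two measured steps bear on this. Putting isopropyl where hydroxymethyl was gave a number 21.3 percentage points higher from compound 1 to compound 2 (beyond the scatter), and then adding a methyl to reach sec-butyl gave a number 14.9 percentage points lower from compound 2 to compound 3 (beyond the scatter). Going by the values given here, both changed what the side chain is made of; here nothing is added or removed, and no measured pair shows such a rearrangement directly. The reasonable expectation is therefore a small step, likely within the scatter, estimated as a number 2.4 percentage points higher from compound 3 to compound 4 (within the scatter), with a little more room downward than upward given where compound 3 already stands.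

Compound 4 is thus expected to give about 43%, with a range from 28% to 60%.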

Compound 4, a percentage reported as activity, at one dose (the size of the read-out at that dose, not a potency): 27.3%
For compound 4 the middle estimate is 15.7 percentage points above the measured one; measured number below the stated range.
By their numbers in this assay, from the lowest: compounds 4, 1 and 3 (each within the scatter of the next, the first and the last beyond it); then compound 2.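

Swapping sec-butyl for isobutyl on this saturated chain carbon keeps the same four carbons and changes only how they are joined, yet in this assay it gives a number 13.3 percentage points lower from compound 3 to compound 4 (beyond the scatter), so at this position the arrangement of the side chain matters and not just its atom count. Isobutyl also gives a number 28.2 percentage points lower from compound 2 to compound 4 (beyond the scatter), while the comparison with the hydroxymethyl side chain gives a number 6.9 percentage points lower from compound 1 to compound 4 (within the scatter), so a side chain made only of carbon does not by itself set a compound apart from the one carrying hydroxymethyl, and isopropyl remains the only side chain whose number lies beyond the scatter of all the others. No measurement shown here explains why these closely related side chains differ.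

The compounds shown leave open how a straight n-butyl chain, a cyclohexyl ring, a benzyl group or a side chain ending in an amine or a carboxylic acid would behave at this position. With a single dose and a single time point in this assay, they also leave open whether these differences would hold at other doses or times.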